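From butyl to sec-butyl on a sulfur

This account rests on a few compounds, and the source may have more. Where it says the series, first, only, none or still open, it means among the compounds named here.

Compound 1, `CCCCSSC(=S)N(CC)CC`, gives no number to work from: in an ADME assay on MCF-10A cells (Homo sapiens) for antiproliferative activity, read by MTT assay, with a stated time of 72 h (on this read-out higher numbers stand for weaker inhibition and lower numbers for stronger inhibition), compound 1 reads > 10000 nM, which is a limit of the assay and not a measured value. Compound 2, `CCCCSSC(=S)N1CCCCC1`, reads > 10000 nM, and this too is a limit. Among the measured compounds shown here, the picture so far is therefore (the limit of > 10000 nM in this assay, at which 2 of the 2 values shown sit), and no measured step connects any two compounds.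

Compound 3, `CCC(C)SSC(=S)N(CC)CC`, keeps the core of compound 1 and carries sec-butyl in place of butyl on a sulfur. In this assay, no step beyond the usual scatter is expected, and no direction is favoured. This expectation rests on compound 1 at > 10000 nM, again a limit. The estimated step that the limit leaves unreadable from compound 1 to compound 3 is accordingly small. Compound 3 is expected at 15000 nM, with an estimated range from 8000 nM to 40000 nM, and it will probably be reported only as a limit.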

Compound 3, half-maximal inhibitory concentration: > 10000 nM
Compound 3 gave a limit, no number; the forecaster's own chance of this, stated with the estimate: 85%; the middle value lies beyond the limit too.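

In this assay compound 3 reads > 10000 nM, a limit and not a number, and since compound 1 also gave only a limit, no step can be read between compound 1 and compound 3. The compounds shown leave open whether sec-butyl in place of butyl on a sulfur changes the activity at all: the limit of > 10000 nM in this assay, at which 3 of the 3 values shown sit.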